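A few compounds are considered here, and "the series" means these few. Any claim that something is new, unique, unknown or untested is made for them only; others in the source may bear on it.

Measured so far in a functional assay on K562 cells (Homo sapiens) for antiproliferative activity; on this read-out higher numbers stand for weaker inhibition of growth and lower numbers for stronger inhibition of growth:
- Compound 1 `COCCCCCCCCCCCCCCC/C=C1/CC(CO)(COC(=O)C(C)(C)C)OC1=O`: 0.138 ug/mL
- Compound 2 `COCCCCCCCCCCCCCCC/C=C1\CC(CO)(COC(=O)C(C)(C)C)OC1=O`: 0.189 ug/mL

Among the compounds with values here, compound 2 stands within the scatter of the only other measured compound, so the two numbers set no order. Compound 3 `COCCCCCCCCCCC/C=C1\CC(CO)(COC(=O)C(C)(C)C)OC1=O` keeps the double-bond geometry of compound 2 but differs in its chain: methoxy in place of 4-methoxybutyl on a saturated chain carbon, ten or more bonds along the chain from a double-bonded chain carbon. Within the data shown here, the only measured step, a 1.4-fold higher number from compound 1 to compound 2 (0.14 log units; within the scatter), changes the double bond from Z to E and leaves the chain untouched, so it gives no size for this change. Among the measured compounds shown here, no measured step shortens the chain. In this assay, a modest move towards a higher number is therefore assumed, with wide uncertainty in size and direction. Compound 3 is expected at 0.28 ug/mL, with an estimated range of 0.07 ug/mL to 1.1 ug/mL. This estimate means an expected 1.5-fold higher number from compound 2 to compound 3 (0.17 log units; within the scatter).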

Compound 3, concentration for 50% growth inhibition: 0.516 ug/mL
Compound 3: the middle estimate sits 1.8-fold (0.27 log units) below what was measured, and the stated range covers the measured number.
By their numbers in this assay, from the lowest: compounds 1 and 2 (each within the scatter of the next); then compound 3.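

In this assay, within the data shown here, the change from 4-methoxybutyl to methoxy, on a saturated chain carbon, brings a 2.7-fold higher number from compound 2 to compound 3 (0.44 log units; beyond the scatter) and so gives the first step here that lies beyond the scatter. The earlier pair, which differs only in double-bond geometry, set no order, whereas this position responds to the change, with the shorter chain going with weaker inhibition of growth. The size of the step is modest, and it comes from this single pair with the methoxy kept and the E geometry held.

On these data alone, what a longer chain, or a hydroxyl or a carboxylic acid in place of the methoxy, would do stays open, as does whether double-bond geometry counts on the shorter chain. Nothing available bears on what lies behind this step.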